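The source may hold more compounds than are shown below. What is called first, only, known or untested is meant among the compounds shown, and "the series" means these compounds.

Measured so far in a functional assay on HT29-AK cells (Homo sapiens) for cytotoxicity, read by MTT assay, with a stated time of 48 h (a higher number here means a weaker inhibitor, a lower number a stronger inhibitor), are these three compounds, each reported only as a limit:
Compound 1 `Fc1cccc(Nc2nc(-c3cccc(F)c3)nc3ccc(F)cc23)c1` gives > 50000 nM as a limit
Compound 2 `Fc1cccc(-c2nc(Nc3cccc(Cl)c3)c3cc(F)ccc3n2)c1` gives > 50000 nM as a limit
Compound 3 `Oc1ccc(Nc2nc(-c3cccc(F)c3)nc3ccc(F)cc23)cc1` gives > 50000 nM as a limit

Compound 3 thus stands at a limit of the assay and not at a number. The set as a whole shows the limit of > 50000 nM in this assay, at which 3 of the 3 values shown sit, and nothing finer.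

Compound 4 `Cc1ccc(Nc2nc(-c3cccc(F)c3)nc3ccc(F)cc23)cc1` has methyl in place of hydroxy on an aromatic carbon, a difference that counts as methyl in place of hydroxy on an aromatic carbon and leaves the rest of compound 3 unchanged. The nearest measured changes, both at the group on the nitrogen, are a step that the two limits leave unreadable from compound 1 to compound 3 and a step that the two limits leave unreadable from compound 2 to compound 3 and neither supplies a size. The change a step that the two limits leave unreadable from compound 1 to compound 2 adds none either.

No direction can be drawn from these, so compound 4 is expected to stay close to compound 3 in this assay and most likely to be reported as a limit again. The expected change is a number no higher from compound 3 to compound 4 (the limit leaves the size open) and no more can be said of it. Compound 4 is estimated at 50000 nM with an expected range from 20000 nM to 80000 nM in this measurement.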

Compound 4, half-maximal inhibitory concentration: > 50000 nM
Compound 4: only a limit was reported; the forecaster's own chance of this, stated with the estimate: 75%; the middle value lies on the limit itself.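

With compound 4 reported only as a limit in this assay, no step among compound 1, compound 2, compound 3 and compound 4 can be read: the limit of > 50000 nM in this assay, at which 4 of the 4 values shown sit.

The compounds shown leave open whether changing the group on the nitrogen alters the read-out at all, since none of them gives a number.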